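Methyl in Place of Pyrrolidin-1-yl on a Sulfonyl Sulfur

A few compounds are considered here, and "the series" means these few. Any claim that something is new, unique, unknown or untested is made for them only; others in the source may bear on it.

Values measured in an ADME assay on HepG2 cells (Homo sapiens) for cytotoxicity, read by MTT assay, with a stated time of 48 h (a lower number here means a stronger inhibitor, a higher number a weaker inhibitor), are shown here:
- Compound 1 `O=S(=O)(c1cccc(-c2ccc3ncnc(Nc4ccc(OCc5cccc(F)c5)c(Cl)c4)c3c2)c1)N1CCOCC1` gives > 15000 nM
- Compound 2 `O=S(=O)(c1ccc(-c2ccc3ncnc(Nc4ccc(OCc5cccc(F)c5)c(Cl)c4)c3c2)cc1)N1CCCC1` gives > 15000 nM

Compound 1 gives > 15000 nM and this is a limit of the assay, not a number. Compound 2 gives > 15000 nM and this too is a limit of the assay, not a number. Among the measured compounds shown here, compound 2 thus stands at the limit of > 15000 nM in this assay, at which 2 of the 2 values shown sit, and no measured step exists to serve as a guide.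

The next compound is compound 3 `CS(=O)(=O)c1ccc(-c2ccc3ncnc(Nc4ccc(OCc5cccc(F)c5)c(Cl)c4)c3c2)cc1` which carries methyl in place of pyrrolidin-1-yl on a sulfonyl sulfur. Counted out, the change is methyl in place of pyrrolidin-1-yl on a sulfonyl sulfur and the rest of the structure stays the same.

In this assay no shift beyond the usual scatter is expected in either direction, and the estimate is a step that the limit leaves unreadable from compound 2 to compound 3 for this swap. For compound 3 the expected value is 16000 nM within an estimated range of 8000 nM to 30000 nM in this assay.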

Compound 3, half-maximal inhibitory concentration: > 15000 nM
Compound 3: no number, only a limit (the forecaster's own chance of this, stated with the estimate: 70%); the middle value is on the limit's open side.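

In this assay, among the compounds shown here, compound 2 and compound 3 both give a limit of the assay rather than a number, so no step between them can be read: the limit of > 15000 nM in this assay, at which 3 of the 3 values shown sit. The compounds shown leave open whether methyl in place of pyrrolidin-1-yl on a sulfonyl sulfur changes the read-out at all.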